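A few compounds are considered here, and "the series" means these few. Any claim that something is new, unique, unknown or untested is made for them only; others in the source may bear on it.

Working notes on the series. Compound 1 `O=C(O)CC(NS(=O)(=O)c1ccccc1)c1ccccc1F` stands at > 100000 nM in a functional assay on MDA-MB-231 cells (Homo sapiens) for antiproliferative activity, read by MTT assay, with a stated time of 24 h (a lower number here means a stronger inhibitor, a higher number a weaker inhibitor), and this is a limit of the assay, not a number. Compound 2 `O=C(O)CC(NS(=O)(=O)c1ccc(C(F)(F)F)cc1)c1ccccc1F` gives 47100 nM in this assay. The change to compound 3 `O=C(O)CC(NS(=O)(=O)c1cc(F)cc(F)c1)c1ccccc1F` is 3,5-difluorophenyl in place of phenyl on a sulfonyl sulfur. Within the data shown here, the only measured step that bears on it is an at least 2.1-fold lower number from compound 1 to compound 2 (0.32 log units; beyond the scatter), and that step involves a different substituent, so it is a loose guide. A modest move towards a lower number is expected in this assay. The estimated step is an at least 1.4-fold lower number from compound 1 to compound 3 (0.15 log units; that floor lies within the scatter). For compound 3 the expected value is 70000 nM, with an estimated range of 35000 nM to 130000 nM.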

Compound 3, half-maximal inhibitory concentration: 73500 nM
Compound 3: middle estimate off by 1.1-fold (0.02 log units), on the low side; the range from low to high includes it.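

In this assay, the sulfonyl sulfur position now has a second substituted aryl group that gives a number, as compound 3 joins compound 2 in reading as a value. The change to 3,5-difluorophenyl gives an at least 1.3-fold lower number from compound 1 to compound 3 (0.13 log units; that floor lies within the scatter), so this step alone does not establish a real shift. Compound 1 remains a limit and not a number: the limit of > 100000 nM in this assay, at which 1 of the 3 values shown sits.

From the compounds shown here alone, how far compound 1 lies past that limit stays open, and with it the true size of the step. Also open, going by these compounds, is how an amine or a methoxy group on the sulfonyl aryl ring would read.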